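Trading 4-nitrophenyl for 2,6-dichlorophenyl in compound 3

This account rests on a few compounds, and the source may have more. Where it says the series, first, only, none or still open, it means among the compounds named here.

In a functional assay on Caco-2 cells (Homo sapiens) for inhibition, read by MTT assay, with a stated time of 48 h, tested at 10 uM (on this read-out higher numbers stand for more inhibition of growth at the one concentration tested and lower numbers for less inhibition of growth), compound 1 (`Cc1cc(=O)c2c(O)cc(OCc3ccccc3)c([C@H]3CCN(C)C[C@H]3O)c2o1`) gives 18% and compound 2 (`Cc1oc2c([C@H]3CCN(C)C[C@H]3O)c(O)cc(O)c2c(=O)c1C(O)c1ccc([N+](=O)[O-])cc1`) gives 5% as the lower of the two numbers, a gap beyond the usual scatter. Compound 3 (`Cc1oc2c([C@H]3CCN(C)C[C@H]3O)c(O)cc(O)c2c(=O)c1C(O)c1c(Cl)cccc1Cl`) has not been measured yet. It carries 2,6-dichlorophenyl in place of 4-nitrophenyl on a saturated chain carbon bound to an aromatic carbon and an oxygen on a saturated carbon. Among the compounds with values here, no measured pair shows this swap. Compound 2 at 5% has little room to fall. A small rise, not clearly beyond the scatter, is therefore expected (a number 5 percentage points higher from compound 2 to compound 3 (within the scatter)). Compound 3 is estimated at 10% (expected range 0% to 24%).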

Compound 3, percent growth inhibition at one concentration: 24%
Estimate against measurement, compound 3: 14 percentage points below; measured number inside the range.
By their numbers in this assay, from the lowest: compound 2; then compounds 1 and 3 (each within the scatter of the next).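

In this assay, putting 2,6-dichlorophenyl in place of 4-nitrophenyl on this saturated chain carbon gives a number 19 percentage points higher from compound 2 to compound 3 (beyond the scatter) on an otherwise unchanged structure. Within the data shown here, this is the first sign that the number responds to the aromatic group at this position. Nothing measured here explains the step.

One swap changes the whole group at once, so it cannot separate the effect of adding the two chlorines from that of removing the nitro group. Plain phenyl or 4-aminophenyl at this carbon remains an open case.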